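Methoxy for Fluoro Across Two Related Cores

The compounds below may be only part of what the source reports. "The series", "measured", "known", "first", "only" and "open" are said of these compounds alone.

Measured compounds:
compound 1, `O=C(O)CN1C(=O)/C(=C/c2nc3cc(F)ccc3n2Cc2ccccc2F)SC1=S`, gives 22400 nM
compound 2, `O=C(O)CN1C(=O)/C(=C/c2nc3ccc(F)cc3n2Cc2ccccc2F)SC1=S`, gives only a limit of the assay, > 50000 nM
compound 3, `COc1ccc2c(c1)nc(/C=C1\SC(=S)N(CC(=O)O)C1=O)n2Cc1ccccc1F`, gives 16900 nM

All three were tested in a functional assay on MDA-MB-231 cells (Homo sapiens) for cytotoxicity, read by MTT assay, with a stated time of 48 h; on this read-out higher numbers stand for weaker inhibition and lower numbers for stronger inhibition. Compound 1 and compound 3 both give numbers in this assay, whereas compound 2 gives only a limit, > 50000 nM, and so has no number of its own. Compound 1 and compound 2 are built from the same atoms joined differently; the difference between the two cores is not broken down here.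

Compound 3 differs from compound 1 in one place, by methoxy in place of fluoro on an aromatic carbon. This change made a step of a 1.3-fold lower number from compound 1 to compound 3 (0.12 log units; within the scatter), so the two numbers cannot be told apart by this assay.

Compound 4, `COc1ccc2nc(/C=C3\SC(=S)N(CC(=O)O)C3=O)n(Cc3ccccc3F)c2c1`, has not been measured. Within the data shown here, it differs from compound 2 by methoxy in place of fluoro on an aromatic carbon, which is the same change as the one from compound 1 to compound 3, at the same kind of place. Compound 2 sits at the limit of > 50000 nM in this assay, at which 1 of the 3 values shown sits, so there is no number to anchor the step from.

Resting on the step of a 1.3-fold lower number from compound 1 to compound 3 (0.12 log units; within the scatter), compound 4 is expected to move by about a number no higher from compound 2 to compound 4 (the limit leaves the size open) from where compound 2 stands. Compound 4 is therefore estimated at 50000 nM, with a likely range from 20000 nM to 120000 nM, and it is quite possible that this assay again reports only a limit.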

Compound 4, half-maximal inhibitory concentration: 22400 nM
The estimate for compound 4 lay 2.2-fold (0.35 log units) above the measured number; low and high end bracket the measured number.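

In this assay, methoxy in place of fluoro on an aromatic carbon gave an at least 2.2-fold lower number from compound 2 to compound 4 (0.34 log units; beyond the scatter). From the compounds shown here alone, compound 2 stands at a limit of the assay, > 50000 nM, and not at a true number, so this step sets only the smallest size the change could have, and its real size stays unknown. The result therefore shows that the change can lower the number on this core, but it does not show whether the step carries over from one core to the other at the same size: the same change on two cores in this assay, a 1.3-fold lower number (0.12 log units; within the scatter) from compound 1 to compound 3 and an at least 2.2-fold lower number (0.34 log units; beyond the scatter) from compound 2 to compound 4; the limit leaves it open whether they differ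

The compounds shown have only fluoro and methoxy at this place, which leaves open how other groups there, such as an amine, a nitrile or a longer chain like butoxy, would read in this assay. They also leave open how the same change from fluoro to methoxy would behave on either core with an amide in place of the carboxylic acid that all four compounds carry.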